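Fluorine to Cyclopropyl on the Aryl Ring of a Glucagon Antagonist

A few compounds are considered here, and "the series" means these few. Any claim that something is new, unique, unknown or untested is made for them only; others in the source may bear on it.

Measured compounds in a functional assay on CHO cells for antagonist activity at Glucagon receptor (Homo sapiens), read by cAMP accumulation, with stated times of 30 min and 45 min; on this read-out lower numbers stand for stronger inhibition and higher numbers for weaker inhibition:
- compound 1 `C[C@H](c1ccc(C(=O)NCCC(=O)O)cc1)N1C(=O)C(c2ccccc2F)=N[C@]12CC[C@@H](C(C)(C)C)CC2`: 350 nM
- compound 2 `C[C@H](c1ccc(C(=O)NCCC(=O)O)cc1)N1C(=O)C(c2ccc(F)cc2)=N[C@]12CC[C@@H](C(C)(C)C)CC2`: 430 nM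
- compound 3 `C[C@H](c1ccc(C(=O)NCCC(=O)O)cc1)N1C(=O)C(c2cccc(F)c2)=N[C@]12CC[C@@H](C(C)(C)C)CC2`: 560 nM

All three share one core and differ only in where a single fluorine sits on the aryl ring. Compound 3 cannot be separated from the others, since the measured steps are a 1.6-fold higher number from compound 1 to compound 3 (0.20 log units; within the scatter) and a 1.3-fold higher number from compound 2 to compound 3 (0.11 log units; within the scatter), both within the scatter, as is a 1.2-fold higher number from compound 1 to compound 2 (0.09 log units; within the scatter).

Compound 4 `C[C@H](c1ccc(C(=O)NCCC(=O)O)cc1)N1C(=O)C(c2cccc(C3CC3)c2)=N[C@]12CC[C@@H](C(C)(C)C)CC2` changes that position differently: cyclopropyl in place of fluoro on an aromatic carbon. Going by the values given here, no measured step removes fluorine or introduces cyclopropyl, so the three fluorine shifts offer only indirect guidance; they show the ring tolerates variation without movement beyond the scatter. The step of a 1.1-fold lower number from compound 3 to compound 4 (0.05 log units; within the scatter) is therefore expected to be small, with no clear direction. Compound 4 is estimated at 500 nM, within a range from 180 nM to 1400 nM.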

Compound 4, half-maximal inhibitory concentration: 340 nM
For compound 4 the middle estimate is 1.5-fold (0.17 log units) above the measured one; the measured number falls inside the stated range.
By their numbers in this assay, from the lowest: compounds 4, 1, 2 and 3 (each within the scatter of the next).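

Cyclopropyl, with its 3 carbons and a ring, can replace the single fluorine at this position with no change beyond the scatter of this assay, as the step is a 1.6-fold lower number from compound 3 to compound 4 (0.22 log units; within the scatter). The same holds against the two other fluorine compounds, with a 1.3-fold lower number from compound 2 to compound 4 (0.10 log units; within the scatter) and a 1.0-fold lower number from compound 1 to compound 4 (0.01 log units; within the scatter). Nothing measured here explains why this position accepts the larger group.

From the compounds shown here alone, whether an amine, a carboxylic acid or a longer carbon chain on this carbon would also leave the number within the scatter remains open.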